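Fluoro in place of nitro on compound 1

The source may hold more compounds than are shown below. What is called first, only, known or untested is meant among the compounds shown, and "the series" means these compounds.

In a physicochemical assay, with a stated time of 6 min (a higher number here means a weaker inhibitor, a lower number a stronger inhibitor), compound 1 (`O=C(Nc1ccc([N+](=O)[O-])cc1)Nc1nc(-c2cc3cc(Br)ccc3o2)cs1`) gives > 200000 nM, which is a limit of the assay and not a number. Compound 2 (`O=C(Nc1ccc([N+](=O)[O-])cc1)Nc1nc(-c2cc3ccccc3o2)cs1`) has hydrogen in place of the bromo and gives 19300 nM. Among the measured compounds shown here, that change is the only measured step, a large one beyond the scatter: an at least 10-fold lower number from compound 1 to compound 2 (1.01 log units; beyond the scatter). Compound 3 (`O=C(Nc1ccc(F)cc1)Nc1nc(-c2cc3cc(Br)ccc3o2)cs1`) keeps the bromo and has fluoro in place of nitro on an aromatic carbon, 4-nitrophenyl becoming 4-fluorophenyl: fluoro in place of nitro on an aromatic carbon. For the measured compounds named here, no measured step covers this exchange, so its size remains open. With the bromo kept, the number in this assay is expected to stay high, and a modest move to a lower number is the working expectation. The expected step is an at least 2.5-fold lower number from compound 1 to compound 3 (0.39 log units; beyond the scatter). For compound 3 the estimated value is 80000 nM, with an expected range from 15000 nM to 200000 nM.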

Compound 3, half-maximal inhibitory concentration: > 200000 nM
Compound 3 was reported as a limit (the forecaster's own chance of this, stated with the estimate: 40%); middle value at least 2.5-fold (0.39 log units) away from the limit.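

Compound 1 and compound 3 both stand at a limit of this assay, so the exchange of nitro for fluoro gives no readable step between them: the limit of > 200000 nM in this assay, at which 2 of the 3 values shown sit.

The compounds shown leave open what fluoro in place of nitro gives when the bromo is replaced by hydrogen, as in compound 2.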